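The compounds below may be only part of what the source reports. "The series", "measured", "known", "first", "only" and "open" are said of these compounds alone.

Compound 2, whose structure is `O=C1O[C@@H](CNC(=O)C(F)(F)F)CN1c1ccc(-n2cc(-c3ccccn3)cn2)c(F)c1`, is known in a physicochemical assay for lipophilicity, read by HPLC, measured as octanol-water partition (a higher number here means a more lipophilic compound, a lower number a more polar compound), only as a limit: in this assay compound 2 gives >= 1.78, which is a bound rather than a number. Its nearest measured neighbour is compound 1, with structure `CCC(=O)NC[C@H]1CN(c2ccc(-n3cc(-c4ccccn4)cn3)c(F)c2)C(=O)O1`; in this assay compound 1 gives 2.2. Among the measured compounds shown here, the one measured step, a step that the limit leaves unreadable from compound 1 to compound 2, cannot be read in size, since the limit of >= 1.78 in this assay, at which 1 of the 2 values shown sits, marks the bound on which compound 2 sits. The unmeasured compound 3 has the structure `CNC(=O)[C@H]1CN(c2ccc(-n3cc(-c4ccccn4)cn3)c(F)c2)C(=O)O1`; it differs from compound 2 by methylcarbamoyl in place of (((trifluoromethyl)carbonyl)amino)methyl on a saturated ring carbon. For the measured compounds named here, no measured step mirrors this change, so the bound on compound 2 gives no readable size to carry over. With that in mind, a downward step a number at least 0.28 log units lower from compound 2 to compound 3 (that floor lies within the scatter) is expected, beyond the scatter. For compound 3 in this assay the estimate is 1.5, with a range from 0.9 to 2.1.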

Compound 3, partition coefficient: 1.39
Beside the measured number, compound 3's estimate is 0.11 log units above it; measured number inside the range.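

In this assay, among the compounds shown here, methylcarbamoyl in place of (propanoylamino)methyl on this saturated ring carbon comes out as a number 0.81 log units lower from compound 1 to compound 3 (beyond the scatter), the first step at this position whose size can be read. Methylcarbamoyl in place of (((trifluoromethyl)carbonyl)amino)methyl comes out as a number at least 0.39 log units lower from compound 2 to compound 3 (beyond the scatter), so both exchanges at this ring carbon end lower by more than the scatter. The second step rests on a limit for compound 2, not on a number: the limit of >= 1.78 in this assay, at which 1 of the 3 values shown sits.

On these data alone, whether an amine, a carboxylic acid or a longer chain on this ring carbon would give a step of similar size remains open, as does the step from compound 1 to compound 2, which cannot be read. The compounds shown also do not tell which part of the exchanged chain accounts for the step.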